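This account rests on a few compounds, and the source may have more. Where it says the series, first, only, none or still open, it means among the compounds named here.

Working notes on the series in a functional assay on NCI-H292 cells (Homo sapiens) for antiproliferative activity; a higher number here means a weaker inhibitor, a lower number a stronger inhibitor.

Compound 3 is `O=C1N/C(=C\c2ccc(O)cc2)C(=O)N1c1cccc(Br)c1`. In this assay compound 3 gives only a limit, > 200000 nM. Compound 1 is `O=C1N/C(=C\c2ccc(O)cc2)C(=O)N1c1cccc(I)c1`. In this assay compound 1 gives only a limit, > 200000 nM. Compound 2 is `Cc1cccc(N2C(=O)N/C(=C\c3ccc(O)cc3)C2=O)c1`. In this assay compound 2 gives only a limit, > 200000 nM. Thus compound 3 stands where both of its neighbours stand, at the limit of > 200000 nM in this assay, at which 3 of the 3 values shown sit. The three steps among them, a step that the two limits leave unreadable from compound 1 to compound 2, a step that the two limits leave unreadable from compound 1 to compound 3 and a step that the two limits leave unreadable from compound 2 to compound 3, give no readable size.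

Compound 4 is `O=C(Nc1ccc(Cl)cc1)c1cccc(N2C(=O)N/C(=C\c3ccc(O)cc3)C2=O)c1`. It differs from compound 3 as follows: (4-chlorophenyl)carbamoyl in place of bromo on an aromatic carbon. Among the compounds with values here, none of the measured steps concerns a change of this kind, and all three sit at the limit, so no size or direction can be read for the step to compound 4. The step from compound 3 to compound 4 is therefore estimated only as an at least 2.0-fold lower number from compound 3 to compound 4 (0.30 log units; that floor lies within the scatter), with wide uncertainty. Compound 4 is expected at about 100000 nM, within 10000 nM to 300000 nM.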

Compound 4, half-maximal inhibitory concentration: 125000 nM
The estimate for compound 4 lay 1.3-fold (0.10 log units) below the measured number, within the range that was stated.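

In this assay, putting (4-chlorophenyl)carbamoyl at this aromatic carbon gives the only number in the series shown that is not a limit, so this position can carry a far larger group, with a further six-membered aromatic ring, without the read-out being lost. The change reads as an at least 1.6-fold lower number from compound 3 to compound 4 (0.20 log units; that floor lies within the scatter), as an at least 1.6-fold lower number from compound 2 to compound 4 (0.20 log units; that floor lies within the scatter) and as an at least 1.6-fold lower number from compound 1 to compound 4 (0.20 log units; that floor lies within the scatter), so none of these floors establishes a real gain on its own. The steps among compounds 1, 2 and 3 remain unreadable, and those three compounds stay unresolved from one another: the limit of > 200000 nM in this assay, at which 3 of the 4 values shown sit.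

On these data alone, it remains open which part of the (4-chlorophenyl)carbamoyl group goes with the measurable value: the amide, the ring or the chlorine. Also open, as far as these compounds go, is how a carboxylic acid or an amine at the same carbon would read.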